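Stripping the Amide Aryl Down to Phenyl

The source may hold more compounds than are shown below. What is called first, only, known or untested is meant among the compounds shown, and "the series" means these compounds.

Compound 1 `COc1cc(-c2nn(-c3cccc(NC(=O)c4cccc(C(F)(F)F)c4)c3)cc2-c2ccncc2)ccc1Cl` gives > 50000 nM in a functional assay on T47D cells (Homo sapiens) for inhibition, read by sulforhodamine B assay, with a stated time of 48 h (on this read-out lower numbers stand for stronger inhibition of growth and higher numbers for weaker inhibition of growth), a limit of the assay.
Compound 2 `COc1cc(-c2nn(-c3cccc(NC(=O)c4ccc(Cl)c(C(F)(F)F)c4)c3)cc2-c2ccncc2)ccc1Cl` gives > 32500 nM in this assay, likewise a limit.
Compound 3 `COc1cc(-c2nn(-c3cccc(NC(=O)Nc4ccc(Cl)c(C(F)(F)F)c4)c3)cc2-c2ccncc2)ccc1Cl` gives > 32500 nM in this assay, again a limit.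

Compound 3 therefore stands nowhere in particular: every value shown is a limit, with two sitting at the limit of > 32500 nM in this assay, at which 2 of the 3 values shown sit, and one at the limit of > 50000 nM in this assay, at which 1 of the 3 values shown sits. The steps that lead to it, a step that the two limits leave unreadable from compound 1 to compound 3 and a step that the two limits leave unreadable from compound 2 to compound 3, cannot be read, and a step that the two limits leave unreadable from compound 1 to compound 2 is no better. Compound 4 `COc1cc(-c2nn(-c3cccc(NC(=O)c4ccccc4)c3)cc2-c2ccncc2)ccc1Cl` differs from compound 3 by phenyl in place of (4-chloro-3-(trifluoromethyl)phenyl)amino on a carbonyl carbon. Among the compounds with values here, no measured step bears on this change, so no direction can be expected beyond the scatter, and the step from compound 3 to compound 4 is estimated as a step that the limit leaves unreadable from compound 3 to compound 4. Compound 4 is accordingly expected to give about 40000 nM in this assay, within 15000 nM to 100000 nM, most likely again as a limit.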

Compound 4, concentration for total growth inhibition: > 100000 nM
Compound 4 gave a limit, no number; the forecaster's own chance of this, stated with the estimate: 75%; middle value at least 2.5-fold (0.39 log units) from the limit.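

Compound 4, like compound 1, compound 2 and compound 3, gives only a limit, so none of its steps to those compounds can be read. The compounds shown leave open whether any of these changes alters growth inhibition in this assay.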